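The source may report more compounds than this note shows. Statements on the series, on what has been measured and on what is new or still open speak of the compounds shown alone.

Working notes on the series. Compound 1 `CSCC[C@H](NC(=O)CN(c1nc(Cl)nc2[nH]cnc12)C1CC1)C(=O)OCc1ccccc1` is the benzyl ester of the set. In a functional assay on the whole organism (Tail, strain ICR) with Mus musculus as the target, in the tail flick test, with a stated time of 30 min, at a dose of 25 umol/kg by the oral route (a lower number here means a weaker effect, a higher number a stronger effect of the compound at the dose given), compound 1 gives 22.2%, the second highest of the three numbers. Compound 2 `O=C(O)CC[C@H](NC(=O)CN(c1nc(Cl)nc2[nH]cnc12)C1CC1)C(=O)O` gives 26.8% and compound 3 `CSCC[C@H](NC(=O)CN(c1nc(Cl)nc2[nH]cnc12)C1CC1)C(=O)O` gives 20.4%; the steps of a number 1.8 percentage points lower from compound 1 to compound 3 (within the scatter) and a number 6.4 percentage points lower from compound 2 to compound 3 (within the scatter) both lie within the scatter, so the three measured compounds are not separated. Compound 4 `O=C(CN(c1nc(Cl)nc2[nH]cnc12)C1CC1)N[C@@H](CO)C(=O)OCc1ccccc1` differs from compound 1 by hydroxy in place of (methylsulfanyl)methyl on a saturated chain carbon, two bonds along the chain from an amide-type nitrogen and a carbonyl carbon. Within the data shown here, the one measured step that exchanges a group on a saturated chain carbon, a number 6.4 percentage points lower from compound 2 to compound 3 (within the scatter), stayed within the scatter, and no measured step bears on a hydroxy group. For this assay no step beyond the scatter is therefore expected. Compound 4 is expected to give 22%, within 10% to 35%, which means an expected step of a number 0.2 percentage points lower from compound 1 to compound 4 (within the scatter).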

Compound 4, a percentage reported as activity, at one dose (the size of the read-out at that dose, not a potency): 31.9%
The estimate for compound 4 lay 9.9 percentage points below the measured number, within the range that was stated.
By their numbers in this assay, from the lowest: compounds 3, 1, 2 and 4 (each within the scatter of the next, the first and the last beyond it).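

At the saturated chain carbon, two bonds along the chain from an amide-type nitrogen and a carbonyl carbon, hydroxy in place of (methylsulfanyl)methyl with the benzyl ester kept gives a number 9.7 percentage points higher from compound 1 to compound 4 (within the scatter) in this assay. This exchange therefore does not separate compound 4 from compound 1, even though a sulfur-bearing chain gives way to a single oxygen with a hydrogen-bond donor. No data at hand bear on the reason for this result. From the compounds shown here alone, whether an amine or a phenyl ring on this carbon would separate from compound 1 remains open, as does whether hydroxy here would behave the same way with the free carboxylic acid in place of the benzyl ester.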